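Substituent effects on agonist efficacy in the shared core

The compounds below may be only part of what the source reports. "The series", "measured", "known", "first", "only" and "open" are said of these compounds alone.

Compound 2 `c1ccc2c(c1)CCC2c1ncc[nH]1` stands highest of the two measured numbers in a functional assay on CHO cells for agonist activity at Alpha-1A adrenergic receptor (Homo sapiens), read by FLIPR and calcium flux (on this read-out higher numbers stand for larger maximal responses and lower numbers for smaller maximal responses), giving 54%. Among the compounds with values here, compound 1 `Cn1ccc(-c2cccc3c2CCC3c2ncc[nH]2)n1` gives 19% in this assay; the single measured step, a number 35 percentage points higher from compound 1 to compound 2 (beyond the scatter), shows the response rising when an aromatic substituent is removed. Compound 3 `CS(=O)(=O)Nc1cccc2c1CCC2c1ncc[nH]1` differs from compound 2 by methanesulfonamido in place of hydrogen on an aromatic carbon. This runs opposite to that step, adding a group on an aromatic carbon of the core as compound 1 carries one, so a decrease beyond the scatter is expected, though the entering group differs from that of compound 1 and the size is uncertain. The step is expected to be a number 22 percentage points lower from compound 2 to compound 3 (beyond the scatter). Compound 3 is estimated at 32%, within 12% to 58%.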

Compound 3, largest response reached (Emax), in percent of the reference or control that the assay uses: 87%
For compound 3 the middle estimate is 55 percentage points below the measured one; the measured number lies above the stated range.
By their numbers in this assay, from the lowest: compound 1; then compound 2; then compound 3.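

On this aromatic carbon, adding a group does not by itself lower the response in this assay: methanesulfonamido gives a number 33 percentage points higher from compound 2 to compound 3 (beyond the scatter) and so reverses the direction seen with 1-methyl-1H-pyrazol-3-yl. Exchanging one group for the other gives a number 68 percentage points higher from compound 1 to compound 3 (beyond the scatter) as the widest gap in the series, so the direction depends on the entering group. Nothing available explains why these two groups diverge.

Still open, going by these compounds, is whether an amine or a carboxylic acid on this carbon would raise the response, as methanesulfonamido does, or lower it, as 1-methyl-1H-pyrazol-3-yl does. Also open, on these data alone, is whether a longer chain on the sulfonyl group would hold the level of compound 3.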